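Swapping the terminal aryl group in a pyrrolidine amide series

This account rests on a few compounds, and the source may have more. Where it says the series, first, only, none or still open, it means among the compounds named here.

Three compounds share one core and differ only in the aryl ring at its far end. Compound 1 `Cc1ccccc1-c1ccc(CCC(=O)N2CCCC2)cc1` carries a 2-methylphenyl group, and in an assay on HEK293 cells for inhibition of N-acylethanolamine-hydrolyzing acid amidase (Rattus norvegicus), read by LC-MS, with a stated time of 30 min (on this read-out lower numbers stand for stronger inhibition and higher numbers for weaker inhibition), compound 1 reaches only the limit > 100000 nM, which is a boundary of the assay rather than a number (the limit of > 100000 nM in this assay, at which 1 of the 3 values shown sits). Compound 2 `O=C(CCc1ccc(-c2cccc(F)c2)cc1)N1CCCC1` carries a 3-fluorophenyl group and gives 1800 nM. Compound 3 `O=C(CCc1ccc(-c2ccc(F)cc2)cc1)N1CCCC1` carries a 4-fluorophenyl group and gives 3400 nM; this is the higher of the two numbers, but the step of a 1.9-fold higher number from compound 2 to compound 3 (0.28 log units; within the scatter) lies within the scatter, so the two fluorine isomers cannot be ordered.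

Compound 4 `O=C(CCc1ccc(-c2ccccc2Cl)cc1)N1CCCC1` introduces the change (2-chlorophenyl in place of 4-fluorophenyl on an aromatic carbon). Within the data shown here, the steps that bear on it are an at least 55-fold lower number from compound 1 to compound 2 (1.74 log units; beyond the scatter) and an at least 29-fold lower number from compound 1 to compound 3 (1.46 log units; beyond the scatter), both large, and both run from a ring with a substituent in the 2-position toward a fluorinated ring. Compound 4 returns a substituent to the 2-position, now chlorine, so the move runs back toward the situation of compound 1. A large rise in the number is therefore expected, and the expected step is an 8.8-fold higher number from compound 3 to compound 4 (0.95 log units; beyond the scatter). Compound 4 is expected to give 30000 nM, with a range from 5000 nM to 150000 nM.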

Compound 4, half-maximal inhibitory concentration: > 100000 nM
Compound 4 ended at the assay's limit; the forecaster's own chance of this, stated with the estimate: 40%; middle value at least 3.3-fold (0.52 log units) away from the limit.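

The result shows that the poor outcome of compound 1 was not a one-off tied to its methyl group: in this assay, compound 4, with its 2-chlorophenyl group, also gives > 100000 nM, which is a limit of the assay and not a number. Set against the two fluorinated compounds, the change is large in both comparisons, with an at least 29-fold higher number from compound 3 to compound 4 (1.46 log units; beyond the scatter) and an at least 55-fold higher number from compound 2 to compound 4 (1.74 log units; beyond the scatter), and because compound 4 stands at a limit, its true distance from each could be greater still. Among these four compounds, then, the 2-methylphenyl and 2-chlorophenyl groups both end at the limit, and no compound goes against this, but the step between compound 1 and compound 4 cannot be read because both stand at the same boundary: the limit of > 100000 nM in this assay, at which 2 of the 4 values shown sit.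

As far as these compounds go, what remains open is whether the loss follows the place on the ring or the kind of substituent, since compound 4 changes both at once relative to compound 2 and compound 3. A 2-fluorophenyl group would test the place with the atom held constant, while a 3-chlorophenyl or 4-chlorophenyl group would test chlorine away from the place it holds in compound 4.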